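Replacing Phenyl in Compound 2 With a Carbonyl Group

A few compounds are considered here, and "the series" means these few. Any claim that something is new, unique, unknown or untested is made for them only; others in the source may bear on it.

Of the compounds shown here, three have been tested in an ADME assay on HCT-116 cells (Homo sapiens) for cytotoxicity, read by CellTiter-Glo, with a stated time of 72 h (on this read-out lower numbers stand for stronger inhibition and higher numbers for weaker inhibition), and none gives a number. Compound 1 (`COc1cc(C)ccc1S(=O)(=O)N1CCC(N2CCC(C)CC2)CC1`) stands at a limit (> 5000 nM). Compound 2 (`Cc1cc(C)c(S(=O)(=O)N2CCC(c3ccccc3)CC2)c(C)c1`) also stands at a limit (> 5000 nM). Compound 3 (`CC1CCN(C2CCN(S(=O)(=O)c3cccc(Br)c3)CC2)CC1`) likewise stands at a limit (> 5000 nM).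

Compound 4 (`Cc1cc(C)c(S(=O)(=O)N2CCC(C(=O)N3CCC(C)CC3)CC2)c(C)c1`) carries (4-methylpiperidin-1-yl)carbonyl in place of the phenyl of compound 2, on a saturated ring carbon ((4-methylpiperidin-1-yl)carbonyl in place of phenyl on a saturated ring carbon). For the measured compounds named here, no measured step shows what such a change does. Since compound 2 offers only a limit (> 5000 nM), no step beyond the scatter is expected in this assay. The expected step that the limit leaves unreadable from compound 2 to compound 4 is an estimate only. Compound 4 is expected near 7000 nM within an estimated range of 2500 nM to 20000 nM and will probably be reported as a limit.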

Compound 4, half-maximal inhibitory concentration: > 5000 nM
Compound 4 gave a limit, no number; the forecaster's own chance of this, stated with the estimate: 85%; the middle value is on the limit's open side.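

Compound 4 gives > 5000 nM, which is a limit and not a number. Compound 2 also stands at a limit, so no step can be read between compound 2 and compound 4: the limit of > 5000 nM in this assay, at which 4 of the 4 values shown sit.

From the compounds shown here alone, whether (4-methylpiperidin-1-yl)carbonyl in place of phenyl changes the read-out at all stays open.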